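The source may hold more compounds than are shown below. What is called first, only, known or untested is meant among the compounds shown, and "the series" means these compounds.

Measured so far:
compound 1, `CCCc1cc(Cn2c(CC)nc3c(C)cc(C)nc32)cc(CCC)c1OC(C(=O)O)c1ccc(CC)cc1`, 240 nM in an assay on isolated protein for displacement of a labelled ligand from Type-2 angiotensin II receptor (Rattus norvegicus); a lower number here means a stronger inhibitor, a higher number a weaker inhibitor;
compound 2, `CCCc1cc(Cn2c(CC)nc3c(C)cc(C)nc32)cc(CCC)c1OC(C(=O)O)c1cccc(-c2ccccc2)c1`, 740 nM in this assay.

Compound 2 gives the highest of the two numbers, and its nearest neighbour is compound 1, with the step of a 3.1-fold higher number from compound 1 to compound 2 (0.49 log units; beyond the scatter) separating them. Compound 3, `CCCc1cc(Cn2c(CC)nc3c(C)cc(C)nc32)cc(CCC)c1OC(C(=O)O)c1ccccc1Cl`, is not yet measured. It differs from compound 2 by one change: 2-chlorophenyl in place of 3-phenylphenyl on a saturated chain carbon bound to a carbonyl carbon and an oxygen on an aromatic ring. Among the compounds with values here, only one measured step touches the same place, a 3.1-fold higher number from compound 1 to compound 2 (0.49 log units; beyond the scatter), where a single ring carrying a small group was exchanged for two linked rings and the number rose by a modest amount. Compound 3 moves back to a single ring carrying a small group, though with the chlorine in the 2-position rather than the ethyl in the 4-position of compound 1. A step downward is therefore expected, of roughly a 2.1-fold lower number from compound 2 to compound 3 (0.33 log units; beyond the scatter), landing near compound 1. Compound 3 is estimated at 350 nM, within a range of 100 nM to 1200 nM.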

Compound 3, half-maximal inhibitory concentration: 3500 nM
The estimate for compound 3 lay 10-fold (1.00 log units) below the measured number; the whole stated range lies below it.
By their numbers in this assay, from the lowest: compound 1; then compound 2; then compound 3.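

The smaller group does not bring the number back down at this position: 2-chlorophenyl, with one ring, gives a 4.7-fold higher number from compound 2 to compound 3 (0.67 log units; beyond the scatter) in this assay, even though 3-phenylphenyl has two rings and more heavy atoms. Two groups with a single ring can also lie far apart, with a 15-fold higher number from compound 1 to compound 3 (1.16 log units; beyond the scatter) when 2-chlorophenyl takes the place of 4-ethylphenyl. Across these three compounds, then, the number of rings does not set the order, and what the ring carries matters at this saturated chain carbon. Nothing available explains why this position responds in this way.

As far as these compounds go, compound 1 and compound 3 differ in both the group on the ring and where it sits, so the contribution of each stays open. Also open, from the compounds shown here alone, is how a plain phenyl ring, or a ring carrying a methoxy group, would compare at this position.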